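The compounds below may be only part of what the source reports. "The series", "measured", "known", "first", "only" and "open" are said of these compounds alone.

Series notes. Compound 1 `N=c1oc2ccc(Br)cc2cc1C(=O)NCCO` gives 26% in an assay on CHO cells for displacement of a labelled ligand from adenosine receptor A1 (Homo sapiens), read by scintillation counting, with a stated time of 60 min, tested at 10 uM; on this read-out lower numbers stand for less inhibition and higher numbers for more inhibition at the one concentration tested (going by the name of the read-out). Compound 2 `COc1cccc2cc(C(=O)Nc3c(C#N)ncn3-c3ccccc3)c(=N)oc12` gives 33% in this assay, and compound 3 `COc1ccc(-n2cnc(C#N)c2NC(=O)c2cc3cccc(OC)c3oc2=N)cc1` gives 37% in this assay. Compound 3 sits beyond the scatter above compound 1, while its gap to compound 2 is within the scatter, so compound 3 and compound 2 cannot be ordered on these numbers. Among the compounds with values here, the one measured step, a number 4 percentage points higher from compound 2 to compound 3 (within the scatter), came with methoxy in place of hydrogen on an aromatic carbon and changed nothing beyond the scatter.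

Compound 4 `COc1cccc2cc(C(=O)Nc3c(C#N)ncn3-c3ccc(F)cc3)c(=N)oc12` has not yet been measured in this assay. It differs from compound 3 thus: fluoro in place of methoxy on an aromatic carbon. Within the data shown here, no measured step exchanges fluoro for methoxy, so the nearest evidence is a number 4 percentage points higher from compound 2 to compound 3 (within the scatter), where a methoxy entering on an aromatic carbon moved the number by only a small amount. On that evidence the step from compound 3 to compound 4 is expected to be small, a number 4 percentage points lower from compound 3 to compound 4 (within the scatter), with no direction beyond the scatter. Compound 4 is therefore expected to give 33% in this assay, in a range from 18% to 48%.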

Compound 4, a percentage reported as inhibition, at one concentration (the size of the read-out at that concentration, not a potency): 46%
For compound 4 the middle estimate is 13 percentage points below the measured one; the range from low to high includes it.
By their numbers in this assay, from the lowest: compounds 1, 2, 3 and 4 (each within the scatter of the next, the first and the last beyond it).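

Within the data shown here, at this place, on an aromatic carbon para to a large group, fluoro in place of hydrogen gives the first step beyond the scatter in this assay, with a number 13 percentage points higher from compound 2 to compound 4 (beyond the scatter) and the size of that step modest, whereas methoxy in place of hydrogen gave only a number 4 percentage points higher from compound 2 to compound 3 (within the scatter) at the same place. Fluoro in place of methoxy gives a number 9 percentage points higher from compound 3 to compound 4 (within the scatter), so 4-methoxyphenyl and 4-fluorophenyl cannot be ordered on these numbers, and only the comparison with hydrogen separates the substituents. No measurement at hand accounts for the step from hydrogen to fluoro.

Going by these compounds, whether this step is particular to fluoro remains open, since a chlorine, an amine or a carboxylic acid at the same place would test it. The compounds shown also leave open whether the step would persist with a different group in place of the methoxy on the shared core.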